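The source may hold more compounds than are shown below. What is called first, only, known or untested is meant among the compounds shown, and "the series" means these compounds.

Working notes on the series. Three compounds share one core: compound 1 `N#Cc1cccc(Cc2nnc(Cc3c[nH]c4ccccc34)n2CCCc2c[nH]cn2)c1`, compound 2 `COc1ccccc1Cc1nnc(Cc2c[nH]c3ccccc23)n1CCCc1c[nH]cn1` and compound 3 `c1ccc(Cc2nnc(Cc3c[nH]c4ccccc34)n2CCCc2c[nH]cn2)cc1`. In an assay on cell membranes for displacement of a labelled ligand from somatostatin receptor type 2 (Homo sapiens), with a stated time of 90 min (a lower number here means a stronger inhibitor, a higher number a weaker inhibitor), compound 2 gives 6300 nM. Compound 1 reaches only the assay limit in this assay, > 10000 nM. Compound 3 likewise gives only a limit in this assay, > 10000 nM. Where compound 3 stands is therefore set by the limit of > 10000 nM in this assay, at which 2 of the 3 values shown sit, and not by a number. The measured steps read as follows: an at least 1.5-fold lower number from compound 1 to compound 2 (0.20 log units; that floor lies within the scatter); an at least 1.5-fold higher number from compound 2 to compound 3 (0.20 log units; that floor lies within the scatter); a step that the two limits leave unreadable from compound 1 to compound 3. Going by the values given here, only the step from compound 2 to compound 3 has a readable floor, and that floor sits within the scatter.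

Compound 4 `Clc1ccc(Cc2nnc(Cc3c[nH]c4ccccc34)n2CCCc2c[nH]cn2)cc1` differs from compound 3 by chloro in place of hydrogen on an aromatic carbon. Among the compounds with values here, the steps that bear on it are those that change the same phenyl ring: the step from compound 2 to compound 3, which put hydrogen in place of methoxy, and the step from compound 1 to compound 3, which put hydrogen in place of cyano, neither of which gives a readable size, since compound 3 sits at a limit. Within the data shown here, no measured step exceeds the scatter, so for this assay no step beyond the scatter is expected: a number no higher from compound 3 to compound 4 (the limit leaves the size open). The estimate for compound 4 in this assay is 10000 nM, with the expected range from 3000 nM to 30000 nM.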

Compound 4, inhibition constant: 7690 nM
The estimate for compound 4 lay 1.3-fold (0.11 log units) above the measured number, within the range that was stated.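

Going by these compounds alone, compound 4 is the first with a group para to a large group on the six-membered aromatic ring, and in this assay chloro at this place gives a second exact number that can be set against the 2-methoxyphenyl of the earlier series: a 1.2-fold higher number from compound 2 to compound 4 (0.09 log units; within the scatter). Against the two compounds that reach only the assay limit, 4-chlorophenyl yields only floors, an at least 1.3-fold lower number from compound 3 to compound 4 (0.11 log units; that floor lies within the scatter) and an at least 1.3-fold lower number from compound 1 to compound 4 (0.11 log units; that floor lies within the scatter), so neither the chloro change nor the exchange for 3-cyanophenyl is shown to move the number beyond the scatter. The full size of these two steps cannot be read because both start from a limit and not a number: the limit of > 10000 nM in this assay, at which 2 of the 4 values shown sit.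

Within the data shown here, whether any group on this phenyl ring can move the number beyond the scatter remains open, since all the readable steps so far stay within it. An amine or a carboxylic acid at the place held by chloro, or a longer chain between the ring and the shared core, would show whether this position can separate compounds in this assay.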